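Swapping a Ring for a Branched Chain on Piperazine

This account rests on a few compounds, and the source may have more. Where it says the series, first, only, none or still open, it means among the compounds named here.

Measured compounds:
Compound 1, `CN1CCN(c2nc(Nc3ccc(C#N)c(C(F)(F)F)c3)nc(Oc3ccnc4ccccc34)n2)CC1`: 51200 nM
Compound 2, `N#Cc1ccc(Nc2nc(Oc3ccnc4ccccc34)nc(N3CCN(c4ccccn4)CC3)n2)cc1C(F)(F)F`: 85900 nM

Both values come from a functional assay on DU-145 cells (Homo sapiens) for cytotoxicity, read by sulforhodamine B assay, with a stated time of 48 h; a lower number here means a stronger inhibitor of growth, a higher number a weaker inhibitor of growth. Compound 2 holds the highest of the two numbers, but its nearest neighbour is compound 1, and the step of a 1.7-fold higher number from compound 1 to compound 2 (0.22 log units; within the scatter) stays within the scatter, so the two cannot be ordered with confidence.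

Compound 3, `CC(C)N1CCN(c2nc(Nc3ccc(C#N)c(C(F)(F)F)c3)nc(Oc3ccnc4ccccc34)n2)CC1`, has not yet been measured. It differs from compound 2 in one place: isopropyl in place of pyridin-2-yl on an amine nitrogen in a ring. For the measured compounds named here, only one measured step touches this position, the exchange of methyl for pyridin-2-yl, a 1.7-fold higher number from compound 1 to compound 2 (0.22 log units; within the scatter), which did not move the number beyond the scatter. Isopropyl, like methyl, is a short chain without a ring, so the step of a 1.6-fold lower number from compound 2 to compound 3 (0.19 log units; within the scatter) is expected to be small and, if anything, downward, toward the value of compound 1.

Compound 3 is therefore estimated at 55000 nM, with a range from 20000 nM to 150000 nM.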

Compound 3, concentration for 50% growth inhibition: > 100000 nM
Compound 3: no number, only a limit; the forecaster's own chance of this, stated with the estimate: 20%; middle value at least 1.8-fold (0.25 log units) away from the limit.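

In this assay, compound 3 gives > 100000 nM, which is a limit of the assay and not a number. All that can be read is a floor for each change on this amine nitrogen in a ring: an at least 1.1-fold higher number from compound 2 to compound 3 (0.06 log units; that floor lies within the scatter), and an at least 1.9-fold higher number from compound 1 to compound 3 (0.29 log units; that floor lies within the scatter). With methyl, pyridin-2-yl and isopropyl now tried at this position, no group gives a number that stands clearly apart from the others, and the reading for isopropyl stops at the edge of what was read: the limit of > 100000 nM in this assay, at which 1 of the 3 values shown sits.

From the compounds shown here alone, how far compound 3 lies past its limit stays open, so the true size of both steps is unknown. Also open, going by these compounds, is whether a plain hydrogen, a benzyl group or a longer chain on this nitrogen would give a clearly lower number.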